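Chain extension on a bromine-free core, tested on one acetophenone

The source may report more compounds than this note shows. Statements on the series, on what has been measured and on what is new or still open speak of the compounds shown alone.

Measured compounds:
compound 1, `CCCCCCCCCCOc1cc(OC)c(Br)cc1C(C)=O`, 34700000 nM 
compound 2, `CCCCCCCCCCCCOc1cc(OC)c(Br)cc1C(C)=O`, 32700000 nM 
compound 3, `CCCCOc1cc(OC)ccc1C(C)=O`, 36300000 nM 

Of the compounds shown here, three have been measured in a functional assay, read by spectrophotometry, with a stated time of 6 min; a lower number here means a stronger inhibitor, a higher number a weaker inhibitor. Compound 1 gives 34700000 nM, compound 2 gives 32700000 nM, and compound 3 gives 36300000 nM. All three numbers lie within the scatter of one another, so no order among them can be read. Compound 2 is made from compound 1 by ethyl in place of hydrogen on a saturated chain carbon, ten or more bonds along the chain from an oxygen on an aromatic ring, and that step reads a 1.1-fold lower number from compound 1 to compound 2 (0.03 log units; within the scatter).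

Compound 4, `CCCCCCOc1cc(OC)ccc1C(C)=O`, has not yet been measured in this assay. It is made from compound 3 by ethyl in place of hydrogen on a saturated chain carbon, four bonds along the chain from an oxygen on an aromatic ring. This is the same kind of change as that from compound 1 to compound 2, but the place differs: in the earlier pair the change sits much further along the chain from the oxygen on the aromatic ring, while here it sits four bonds along the chain from that oxygen. The difference between the core of compound 3 and the core of compound 1 is not broken down here.

Given that the earlier step produced a 1.1-fold lower number from compound 1 to compound 2 (0.03 log units; within the scatter), compound 4 is expected to land close to compound 3, with an estimated step of a 1.1-fold lower number from compound 3 to compound 4 (0.03 log units; within the scatter). The estimate for compound 4 in this assay is 34000000 nM, expected to fall between 17000000 nM and 70000000 nM.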

Compound 4, half-maximal inhibitory concentration: 42100000 nM
Beside the measured number, compound 4's estimate is 1.2-fold (0.09 log units) below it, within the range that was stated.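

In this assay, ethyl in place of hydrogen on a saturated chain carbon, four bonds along the chain from an oxygen on an aromatic ring, gives a 1.2-fold higher number from compound 3 to compound 4 (0.06 log units; within the scatter). Set beside the earlier step, the same change reads alike on the two cores, and no difference between them can be claimed: the same change on two cores in this assay, a 1.1-fold lower number (0.03 log units; within the scatter) from compound 1 to compound 2 and a 1.2-fold higher number (0.06 log units; within the scatter) from compound 3 to compound 4, 1.2-fold (0.09 log units) apart, within the scatter of two such steps. This shows that in these two pairs the change leaves the number within the scatter on either core, but it does not show that an effect carries over from one core to the other, since neither step gives a readable effect to carry, and the two steps also sit at different places along the chain, so core and place cannot be told apart.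

All four numbers are very high, and the compounds shown leave open whether anything on these cores would give a step beyond the scatter. From the compounds shown here alone, a longer chain on the core of compound 3, or an amine or a carboxylic acid carried on the chain, remains untested here, as does what the bromine and the other differences between the two cores contribute on their own.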